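Removing the Chloro Group: From Compound 3 to Compound 4

This account rests on a few compounds, and the source may have more. Where it says the series, first, only, none or still open, it means among the compounds named here.

Three compounds were measured in a functional assay with Rattus norvegicus as the target; a higher number here means a weaker inhibitor, a lower number a stronger inhibitor. Compound 1 `N#Cc1ccc(C(=O)/C=C/c2ccncc2)cc1` gives 123000 nM, compound 2 `O=C(/C=C/c1ccncc1)c1ccc(Cl)cc1` gives 60000 nM, and compound 3 `O=C(/C=C/c1ccncc1)c1cccc(Cl)c1` gives 69000 nM. Among these, compound 3 holds the second highest number; its gap to compound 2 lies within the scatter, and so does its gap to compound 1. Going by the values given here, the only single-place step measured is a 2.1-fold lower number from compound 1 to compound 2 (0.31 log units; beyond the scatter). Compound 4 `O=C(/C=C/c1ccncc1)c1ccccc1` differs from compound 3 as follows: hydrogen in place of chloro on an aromatic carbon. Among the compounds with values here, no measured step removes a chloro group, so the expectation rests on the narrow spread of all three values and on the modest size of the one known step. Compound 4 is therefore expected to show a 1.3-fold higher number from compound 3 to compound 4 (0.12 log units; within the scatter), a change not beyond the scatter. The estimate for compound 4 in this assay is 90000 nM, between 40000 nM and 200000 nM.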

Compound 4, half-maximal inhibitory concentration: 49000 nM
Estimate against measurement, compound 4: 1.8-fold (0.26 log units) above, and the stated range covers the measured number.
By their numbers in this assay, from the lowest: compounds 4, 2, 3 and 1 (each within the scatter of the next, the first and the last beyond it).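

Replacing the chloro group that sits meta to a large group with hydrogen gives a 1.4-fold lower number from compound 3 to compound 4 (0.15 log units; within the scatter) in this assay, and the same replacement on the other chloro compound gives a 1.2-fold lower number from compound 2 to compound 4 (0.09 log units; within the scatter); both steps lie within the scatter, so neither chloro group shows a measurable contribution to the number. Replacing cyano with hydrogen gives a 2.5-fold lower number from compound 1 to compound 4 (0.40 log units; beyond the scatter) and lies beyond the scatter, making cyano the only group shown here that separates from hydrogen. Nothing available explains these differences.

From the compounds shown here alone, whether an amine or a methoxy group on this aromatic carbon would shift the number beyond the scatter remains open.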